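The source may report more compounds than this note shows. Statements on the series, on what has been measured and on what is new or still open speak of the compounds shown alone.

The compounds here share one core. In an assay on HeLa cells for inhibition of Indoleamine 2,3-dioxygenase 1 (Homo sapiens), read by spectrophotometry, with a stated time of 24 h (a higher number here means that more compound is needed for the effect, a lower number that less compound is needed), compound 1 `Cc1cccc(NNS(=O)(=O)c2ccc(C(=O)NCC(=O)O)cc2)c1` gives 271 nM. Compound 2 `Cc1cccc(NNS(=O)(=O)c2ccc(C#N)cc2)c1` gives 3400 nM in this assay. Compound 3 `CC(=O)Nc1ccc(S(=O)(=O)NNc2ccccc2)cc1` gives only a limit of the assay in this assay, > 10000 nM. That is the limit of > 10000 nM in this assay, at which 1 of the 3 values shown sits, so compound 3 stands at the far end of the numbers shown, with no exact value of its own.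

Compound 4 `CC(=O)Nc1ccc(S(=O)(=O)NNc2ccc(C)cc2)cc1` differs from compound 3 by methyl in place of hydrogen on an aromatic carbon. Among the compounds with values here, only one step has been measured, and it concerns a different place on the shared core: a 13-fold higher number from compound 1 to compound 2 (1.10 log units; beyond the scatter). Within the data shown here, that step therefore does not bear on the change from compound 3 to compound 4, and no measured step does. With nothing pointing either way, no step beyond the scatter is expected, so that compound 4 is expected to remain near the limit, an estimated step that the limit leaves unreadable from compound 3 to compound 4. Compound 4 is expected at 15000 nM in this assay, with a range from 4000 nM to 60000 nM.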

Compound 4, half-maximal effective concentration: 1170 nM
Beside the measured number, compound 4's estimate is 13-fold (1.11 log units) above it; measured number outside the range, below it.
By their numbers in this assay, from the lowest: compound 1; then compound 4; then compound 2. At a limit, above all of these: compound 3.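

Methyl in place of hydrogen, on an aromatic carbon para to a large group, gives an at least 8.5-fold lower number from compound 3 to compound 4 (0.93 log units; beyond the scatter) in this assay. Within the data shown here, this is the first measured change at this position, and it shows that going from phenyl to 4-methylphenyl, a change of a single carbon, is enough to move a compound from the limit of the assay to a readable value. Compound 3 has only a limit, so this step gives a smallest possible size and not an exact one: the limit of > 10000 nM in this assay, at which 1 of the 4 values shown sits.

The compounds shown leave open whether an ethyl group, an amine or a carboxylic acid at this same place would give a lower or higher number than methyl. They also leave open whether the methyl step would hold with the (carboxymethyl)carbamoyl group of compound 1 in place of the large group.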